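Compound 4 follows compound 3 with an acid in place of an ester

The compounds below may be only part of what the source reports. "The series", "measured", "known", "first", "only" and "open" are said of these compounds alone.

The series shares one core, shown by compound 1 `COc1cc(OC)c(/C=C/S(=O)(=O)Nc2ccc(OC)c(OP(=O)(O)O)c2)c(OC)c1`, which in a functional assay on K562 cells (Homo sapiens) for cytotoxicity, read by trypan blue exclusion, with a stated time of 96 h (on this read-out lower numbers stand for stronger inhibition and higher numbers for weaker inhibition), gives 7.5 nM. Compound 2 `COC(=O)C(C)Nc1cc(NS(=O)(=O)/C=C/c2c(OC)cc(OC)cc2OC)ccc1OC` gives 300 nM in this assay, and compound 3 `COC(=O)C(Nc1cc(NS(=O)(=O)/C=C/c2c(OC)cc(OC)cc2OC)ccc1OC)c1ccc(Br)cc1` gives 1000 nM. On these three numbers compound 3 stands highest: the step of a 3.3-fold higher number from compound 2 to compound 3 (0.52 log units; beyond the scatter) is modest, while the gap to compound 1 is large, built from a 40-fold higher number from compound 1 to compound 2 (1.60 log units; beyond the scatter) together with the further step to compound 3.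

Compound 4 `COc1cc(OC)c(/C=C/S(=O)(=O)Nc2ccc(OC)c(NC(C(=O)O)c3ccc(Cl)cc3)c2)c(OC)c1` has not yet been measured in this assay. It differs from compound 3 in one place: carboxy(4-chlorophenyl)methyl in place of (4-bromophenyl)(methoxycarbonyl)methyl on a nitrogen on an aromatic ring. For the measured compounds named here, no measured step separates a methoxycarbonyl from a carboxy group, nor a 4-bromophenyl from a 4-chlorophenyl; the only step that touches this part of the molecule is a 3.3-fold higher number from compound 2 to compound 3 (0.52 log units; beyond the scatter), where an aryl group first entered and the number rose modestly. Since compound 4 keeps an aryl group there, that step gives no reason to expect a further large move in either direction. Compound 4 is therefore expected to stay close to compound 3, with a step of no change at the digits printed from compound 3 to compound 4 (within the scatter) that should fall within the scatter. The expected number for compound 4 is 1000 nM, ranging from 300 nM to 3000 nM.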

Compound 4, half-maximal inhibitory concentration: 15 nM
Beside the measured number, compound 4's estimate is 67-fold (1.82 log units) above it, and the stated range ends above it.
By their numbers in this assay, from the lowest: compounds 1 and 4 (each within the scatter of the next); then compound 2; then compound 3.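

At the position on a nitrogen on an aromatic ring, carboxy(4-chlorophenyl)methyl in place of (4-bromophenyl)(methoxycarbonyl)methyl gives, in this assay, a 67-fold lower number from compound 3 to compound 4 (1.82 log units; beyond the scatter), which shows that a group carrying an aryl ring at this position need not leave the number high, something the earlier esters could not show. The same group also stands well clear of the smaller 1-(methoxycarbonyl)ethyl, with a 20-fold lower number from compound 2 to compound 4 (1.30 log units; beyond the scatter), and against the group of the core of compound 1 it gives a 2.0-fold higher number from compound 1 to compound 4 (0.30 log units; within the scatter), so a substituent on this nitrogen can match the value of that compound within the scatter. No measurement among those given accounts for this change.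

The change replaces the methyl ester with the free acid and the bromine with chlorine in a single step, so the compounds shown do not separate the share of each. Also open, as far as these compounds go, is how a primary amide in place of the acid, or a 4-fluorophenyl in place of the 4-chlorophenyl, would read at this position.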